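This account rests on a few compounds, and the source may have more. Where it says the series, first, only, none or still open, it means among the compounds named here.

Series with the shared core of compound 1 `COc1ccc(Oc2ccc3c(NCCCNCc4cc(F)ccc4OC)ccnc3c2)cc1`, which in a physicochemical assay for solubility, with a stated time of 18 h, at pH 7.4 (on this read-out lower numbers stand for lower solubility and higher numbers for higher solubility), gives 14500 nM. Compound 2 `COc1ccc(F)cc1CNCCCNc1ccnc2cc(Cc3cccc(C(F)(F)F)c3)ccc12` gives 4200 nM and compound 3 `COc1ccc(F)cc1CNCCCNc1ccnc2cc(CC(C)C)ccc12` gives 4200 nM. The steps of a 3.5-fold lower number from compound 1 to compound 2 (0.54 log units; beyond the scatter) and a 3.5-fold lower number from compound 1 to compound 3 (0.54 log units; beyond the scatter) run in the same direction, while no change at the digits printed from compound 2 to compound 3 (within the scatter). Compound 3 thus sits level with compound 2, the two together the lowest numbers of the three, with compound 1 higher.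

Compound 4 `COc1ccc(F)cc1CNCCCNc1ccnc2cc(-c3cccc4ccccc34)ccc12` differs from compound 3 by naphthalen-1-yl in place of isobutyl on an aromatic carbon. The step from compound 2 to compound 3, swapping a ring-bearing group for a branched chain, bears most directly on this change and was flat; the steps from compound 1 were modest. A modest downward step a 2.3-fold lower number from compound 3 to compound 4 (0.37 log units; beyond the scatter) is therefore expected, and compound 4 is estimated at 1800 nM (range 500 nM to 5000 nM).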

Compound 4, solubility: 32000 nM
Compound 4: middle estimate off by 18-fold (1.25 log units), on the low side, outside the stated range (above it).
By their numbers in this assay, from the lowest: compounds 2 and 3 (each within the scatter of the next); then compound 1; then compound 4.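

At this aromatic carbon, in this assay, naphthalen-1-yl gives a 7.6-fold higher number from compound 3 to compound 4 (0.88 log units; beyond the scatter) and a 7.6-fold higher number from compound 2 to compound 4 (0.88 log units; beyond the scatter) and also a 2.2-fold higher number from compound 1 to compound 4 (0.34 log units; beyond the scatter) and so stands highest of the four. The earlier changes here gave only lower or unchanged numbers, whereas this one shows that the number at this position can also rise past that of compound 1. Nothing available accounts for this rise.

Going by these compounds, whether the rise is particular to naphthalen-1-yl remains open. Also open, on these data alone, is how phenyl, morpholine or a carboxylic acid would compare at this position.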